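Working notes: sulfonyl on the ring amine

The compounds below may be only part of what the source reports. "The series", "measured", "known", "first", "only" and "open" are said of these compounds alone.

compound 1 `O=C1/C(=C/c2cccnc2)CNC/C1=C\c1ccccc1F`: 21000 nM
compound 2 `N#Cc1ccc(S(=O)(=O)N2C/C(=C\c3cccnc3)C(=O)/C(=C/c3ccccc3F)C2)cc1`: 6600 nM
compound 3 `O=C1/C(=C/c2ccncc2)CNC/C1=C\c1ccccc1F`: 8200 nM

In a functional assay on HepG2 cells (Homo sapiens) for cytotoxicity, read by MTT assay, with a stated time of 24 h (on this read-out lower numbers stand for stronger inhibition and higher numbers for weaker inhibition), compound 3, at 8200 nM, cannot be separated from compound 2, at 6600 nM, as the two values lie within the usual scatter of each other. Compound 1 carries the highest number of the set, and pyridin-4-yl in place of pyridin-3-yl gives a 2.6-fold lower number from compound 1 to compound 3 (0.41 log units; beyond the scatter).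

Compound 4 `O=C1/C(=C/c2ccncc2)CN(S(=O)(=O)c2ccc(F)cc2)C/C1=C\c1ccccc1F` carries (4-fluorophenyl)sulfonyl in place of hydrogen on an amine nitrogen in a ring. Within the data shown here, the closest precedent is (4-cyanophenyl)sulfonyl at the same place, a modest change that gave a 3.2-fold lower number from compound 1 to compound 2 (0.50 log units; beyond the scatter). Among the measured compounds shown here, that is a single pair, with a different sulfonyl group and the pyridin-3-yl partner, and no sulfonylated pyridin-4-yl compound has been measured yet. A modest move to a lower number is therefore expected, though it may not clear the scatter. The expected step is a 2.9-fold lower number from compound 3 to compound 4 (0.47 log units; beyond the scatter). For compound 4 the estimated value is 2800 nM, with an expected range of 900 nM to 7500 nM.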

Compound 4, half-maximal inhibitory concentration: 20300 nM
Estimate against measurement, compound 4: 7.3-fold (0.86 log units) below, outside the stated range (above it).
By their numbers in this assay, from the lowest: compounds 2 and 3 (each within the scatter of the next); then compounds 4 and 1 (each within the scatter of the next).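

In this assay, (4-fluorophenyl)sulfonyl in place of hydrogen on an amine nitrogen in a ring gives a 2.5-fold higher number from compound 3 to compound 4 (0.39 log units; beyond the scatter), whereas (4-cyanophenyl)sulfonyl at the same place gave a 3.2-fold lower number from compound 1 to compound 2 (0.50 log units; beyond the scatter). Substitution on this nitrogen therefore does not move the number in one direction across the series: the two steps run opposite ways, each beyond the scatter, and the pairs differ in both the sulfonyl group and the pyridine partner. Nothing available here accounts for the reversal.

The compounds shown leave open whether the direction of the step follows the sulfonyl group or the pyridine partner. Also open, going by these compounds, is how an acetyl or a methylsulfonyl group on the same amine nitrogen would read in this assay.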